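The source may report more compounds than this note shows. Statements on the series, on what has been measured and on what is new or still open speak of the compounds shown alone.

Measured so far in a functional assay on HCT-116 cells (Homo sapiens) for cytotoxicity; on this read-out higher numbers stand for weaker inhibition and lower numbers for stronger inhibition:
- compound 1 `COc1cc(N2CCN(C(=O)N3CCN(C)CC3)CC2)ccc1Nc1nc(NC2CCCCC2)c2nc[nH]c2n1` gives 17 nM
- compound 2 `COc1cc(N2CCN(C(=O)N3CCC(O)C3)CC2)ccc1Nc1nc(NC2CCCCC2)c2nc[nH]c2n1` gives 27 nM
- compound 3 `COc1cc(N2CCC(C(=O)N3CCOCC3)CC2)ccc1Nc1nc(NC2CCCCC2)c2nc[nH]c2n1` gives 50 nM

Compound 3 (50 nM) lies within the usual scatter of compound 2 (27 nM). Compound 1 (17 nM) has the lower number of the pair it forms with compound 3, and the gap between those two lies beyond the scatter. The next compound is compound 4 `CCN(CC)CC1CCN(c2ccc(Nc3nc(NC4CCCCC4)c4nc[nH]c4n3)c(OC)c2)CC1` with (diethylamino)methyl in place of (morpholin-4-yl)carbonyl on a saturated ring carbon. The counted change is (diethylamino)methyl in place of (morpholin-4-yl)carbonyl on a saturated ring carbon and it falls on a six-membered non-aromatic ring with 1 nitrogen.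

For the measured compounds named here, only one measured step offers any guide: a 1.6-fold higher number from compound 1 to compound 2 (0.20 log units; within the scatter) with 3-hydroxypyrrolidin-1-yl in place of 4-methylpiperazin-1-yl on a carbonyl carbon. That step stays within the scatter, but it keeps the carbonyl, so it bears on the new change only loosely. Going by the values given here, no measured compound lacks the carbonyl, so the range must stay wide. In this assay no step beyond the scatter is therefore expected, and the data set no firm direction. The estimate amounts to an expected 1.7-fold lower number from compound 3 to compound 4 (0.22 log units; within the scatter) and so sits among the three measured values. For compound 4 the expected value is 30 nM with an estimated range from 10 nM to 100 nM as its bounds.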

Compound 4, half-maximal inhibitory concentration: 74 nM
Compound 4: middle estimate off by 2.5-fold (0.39 log units), on the low side; measured number inside the range.
By their numbers in this assay, from the lowest: compounds 1, 2, 3 and 4 (each within the scatter of the next, the first and the last beyond it).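

In this assay, the step to (diethylamino)methyl on the saturated ring carbon gives a 1.5-fold higher number from compound 3 to compound 4 (0.17 log units; within the scatter), so at this position the read-out does not move beyond the scatter when the (morpholin-4-yl)carbonyl group leaves. The earlier step kept the carbonyl and changed only the amine attached to it, whereas this one removes the carbonyl and the six-membered ring with 2 hetero atoms, and the entering group has no ring, 6 heavy atoms rather than 8, and 1 hydrogen-bond acceptor rather than 2. No supporting measurement bears on this result, so nothing shown accounts for it.

The compounds shown leave open whether the carbonyl and the morpholine ring matter separately at this position, since both leave in the same step. (Morpholin-4-yl)methyl on the same saturated ring carbon would part the two, while a carboxylic acid or a longer chain there would test whether the read-out stays as close with groups of a different kind.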